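Chloro in place of bromo: a growth-inhibition estimate

A few compounds are considered here, and "the series" means these few. Any claim that something is new, unique, unknown or untested is made for them only; others in the source may bear on it.

Values in a functional assay on U-251 cells (Homo sapiens) (on this read-out lower numbers stand for stronger inhibition of growth and higher numbers for weaker inhibition of growth), are as follows
Compound 1 `O=S(=O)(/C=C/c1ccccc1)Cc1ccc(Nc2ncnc3ccccc23)cc1` gives > 100000 nM as a limit
Compound 2 `O=S(=O)(/C=C/c1ccc(F)cc1)Cc1ccc(Nc2ncnc3ccccc23)cc1` gives 10 nM as a number
Compound 3 `O=S(=O)(/C=C/c1ccc(Br)cc1)Cc1ccc(Nc2ncnc3ccccc23)cc1` gives > 100000 nM as a limit

In this assay compound 3 gives > 100000 nM and that is a limit and not a number. Compound 3 sits at the limit of > 100000 nM in this assay, at which 2 of the 3 values shown sit, and offers no number to start from.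

Compound 4 `O=S(=O)(/C=C/c1ccc(Cl)cc1)Cc1ccc(Nc2ncnc3ccccc23)cc1` carries chloro in place of bromo on an aromatic carbon, para to a large group (chloro in place of bromo on an aromatic carbon). Among the measured compounds shown here, two measured steps bear on this change, and both are large and beyond the scatter. Fluoro in place of hydrogen gave an at least 10000-fold lower number from compound 1 to compound 2 (4.00 log units; beyond the scatter) and bromo in place of fluoro gave an at least 10000-fold higher number from compound 2 to compound 3 (4.00 log units; beyond the scatter) in turn. The step that the two limits leave unreadable from compound 1 to compound 3 adds nothing readable. For the measured compounds named here, the halogen at this place can therefore matter greatly, yet the series has no chloro example, so compound 4 may follow compound 2 or stay with compound 1 and compound 3. A move to a lower number in this assay is expected, of very uncertain size.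

The expected result is an at least 20-fold lower number from compound 3 to compound 4 (1.30 log units; beyond the scatter) as an estimate only. Compound 4 is estimated at 5000 nM with an expected range of 20 nM to 100000 nM in this read-out.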

Compound 4, concentration for 50% growth inhibition: 49000 nM
The estimate for compound 4 lay 9.8-fold (0.99 log units) below the measured number, within the range that was stated.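

In this assay, chloro does not carry the effect of fluoro at this place on the ring (a 4900-fold higher number from compound 2 to compound 4 (3.69 log units; beyond the scatter)), so among the four compounds strong growth inhibition belongs to the 4-fluorophenyl compound alone. Chloro in place of bromo (an at least 2.0-fold lower number from compound 3 to compound 4 (0.30 log units; that floor lies within the scatter)) and chloro in place of hydrogen (an at least 2.0-fold lower number from compound 1 to compound 4 (0.30 log units; that floor lies within the scatter)) are readable only as floors, and neither shows a change that clears the scatter. Compound 1 and compound 3 each stand at a limit and not a number: the limit of > 100000 nM in this assay, at which 2 of the 4 values shown sit.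

The compounds shown leave open whether the effect is unique to fluoro or would also appear with a nitrile, a methoxy or a trifluoromethyl group at this place. They also leave open how far compound 4 really stands from compound 1 and compound 3.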